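A few compounds are considered here, and "the series" means these few. Any claim that something is new, unique, unknown or untested is made for them only; others in the source may bear on it.

Of the compounds shown here, three that share one core have been measured in an assay for displacement of a labelled ligand from growth hormone secretagogue receptor type 1 (Homo sapiens), read by scintillation counting; a lower number here means a stronger inhibitor, a higher number a weaker inhibitor. Compound 1 `Cc1nc2ncc(Oc3ccc(Br)cc3F)cc2c(=O)n1C[C@H]1CCCN(C(C)C)C1` gives 0.16 nM, compound 2 `Cc1nc2cnc(Oc3ccc(F)c4cccnc34)cc2c(=O)n1C[C@H]1CCCN(C(C)C)C1` gives 6.6 nM, and compound 3 `Cc1nc2ncc(Oc3ccc(F)c4cccnc34)nc2c(=O)n1C[C@H]1CCCN(C(C)C)C1` gives 1.9 nM. Compound 3 thus stands between the other two: its number is beyond the scatter below that of compound 2 and beyond the scatter above that of compound 1. Compound 4 `Cc1nc2ncc(Oc3ccc4c(c3)ncn4C)nc2c(=O)n1C[C@H]1CCCN(C(C)C)C1` has not been measured; it differs from compound 3 by 1-methyl-1H-benzimidazol-5-yl in place of 5-fluoroquinolin-8-yl on an oxygen on an aromatic ring. Among the measured compounds shown here, no measured pair shows a change of this kind, so no step size can be read from the data. The step of a 1.6-fold higher number from compound 3 to compound 4 (0.20 log units; within the scatter) is expected to be small, possibly in either direction. Compound 4 is estimated at 3 nM, with a range from 0.6 nM to 15 nM.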

Compound 4, inhibition constant: 5 nM
Estimate against measurement, compound 4: 1.7-fold (0.22 log units) below, and the stated range covers the measured number.
By their numbers in this assay, from the lowest: compound 1; then compound 3; then compounds 4 and 2 (each within the scatter of the next).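

In this assay, among the compounds shown here, 1-methyl-1H-benzimidazol-5-yl in place of 5-fluoroquinolin-8-yl gives a 2.6-fold higher number from compound 3 to compound 4 (0.42 log units; beyond the scatter) as the first step that can be read at this position. Replacing one aromatic group on the oxygen with a different one therefore costs only a modest amount of binding strength, and compound 4 still gives 5 nM in this assay. No measurement shown here explains the change.

Open, going by these compounds, is whether an amine or a carboxylic acid on the benzimidazole would move the number further. Also open, on these data alone, is whether the same swap on the core of compound 2 would give a step of similar size.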